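The compounds below may be only part of what the source reports. "The series", "measured", "known", "first", "only" and "open" are said of these compounds alone.

Measured in a functional assay on MCF7 cells (Homo sapiens) for inhibition, read by MTT assay, with a stated time of 48 h; on this read-out higher numbers stand for weaker inhibition of growth and lower numbers for stronger inhibition of growth:
- compound 1 `Cn1cc(C2CC(c3ccccc3)=NN2C(=O)c2cccnc2)c2ccccc21`: 7200 nM
- compound 2 `Cc1ccc(C(=O)N2N=C(c3ccccc3)CC2c2cn(C)c3ccccc23)cn1`: 4010 nM

Only these two compounds have been measured, and at 4010 nM compound 2 lies within the usual scatter of compound 1. The next compound, compound 3 `Cn1cc(C2CC(c3ccccc3)=NN2C(=O)c2cccnc2Cl)c2ccccc21`, differs from compound 2 as follows: 2-chloropyridin-3-yl in place of 6-methylpyridin-3-yl on a carbonyl carbon. In words, this is 2-chloropyridin-3-yl in place of 6-methylpyridin-3-yl on a carbonyl carbon.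

For the measured compounds named here, one measured step bears on this change, a 1.8-fold lower number from compound 1 to compound 2 (0.25 log units; within the scatter), and it is the addition of a methyl group. Going by the values given here, no measured compound carries chlorine, so the data offer no direct guide to that part of the change. Given only that small step, no shift beyond the scatter is expected in this assay, in either direction. The expected step is a 1.4-fold higher number from compound 2 to compound 3 (0.14 log units; within the scatter). Compound 3 is estimated at 5500 nM, with an expected range of 2400 nM to 13000 nM.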

Compound 3, concentration for 50% growth inhibition: > 10000 nM
Compound 3 gave a limit, no number; the forecaster's own chance of this, stated with the estimate: 5%; middle value at least 1.8-fold (0.25 log units) from the limit.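

In this assay compound 3 gives > 10000 nM, which is a limit of the assay and not a number: the limit of > 10000 nM in this assay, at which 1 of the 3 values shown sits. With 2-chloropyridin-3-yl on the carbonyl carbon in place of 6-methylpyridin-3-yl, the series shows an at least 2.4-fold higher number from compound 2 to compound 3 (0.39 log units; beyond the scatter), so this position, where the methyl step of a 1.8-fold lower number from compound 1 to compound 2 (0.25 log units; within the scatter) had stayed within the scatter, can also carry a change that weakens growth inhibition beyond it. Against the unsubstituted pyridine, chloro in place of hydrogen gives an at least 1.3-fold higher number from compound 1 to compound 3 (0.14 log units; that floor lies within the scatter), and since that floor lies within the scatter, this step alone does not establish a loss.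

From the compounds shown here alone, how far compound 3 lies past its limit remains unknown. Also open, going by these compounds, is whether the loss belongs to chlorine itself or to where it sits on the ring, and how a methoxy group or an amine would read there.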